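Replacing a Chlorophenyl Ring with a Benzodioxin Ring

The source may hold more compounds than are shown below. What is called first, only, known or untested is meant among the compounds shown, and "the series" means these compounds.

Compound 1 `O=S(=O)(NCCCNCc1ccc(Cl)cc1)c1cc(C(F)(F)F)cc(C(F)(F)F)c1` and compound 2 `O=S(=O)(NCCCNCc1cccc(Cl)c1)c1cc(C(F)(F)F)cc(C(F)(F)F)c1` share one core and differ only in where the chlorine sits. In a functional assay on MCF7 cells (Homo sapiens) for inhibition, read by MTT assay, with a stated time of 72 h (on this read-out lower numbers stand for stronger inhibition of growth and higher numbers for weaker inhibition of growth), compound 1 gives 2400 nM, and compound 2 gives 2600 nM; the step of a 1.1-fold higher number from compound 1 to compound 2 (0.03 log units; within the scatter) lies within the scatter, so compound 2 has the highest of the two numbers without being separable from compound 1. Compound 3 `O=S(=O)(NCCCNCC1COc2ccccc2O1)c1cc(C(F)(F)F)cc(C(F)(F)F)c1` carries a larger change: 2,3-dihydro-1,4-benzodioxin-2-yl in place of 3-chlorophenyl on a saturated chain carbon bound to an amine nitrogen. Among the measured compounds shown here, the one measured step only moved a chlorine and is therefore a weak guide. The expected step of no change at the digits printed from compound 2 to compound 3 (within the scatter) is none beyond the scatter, so compound 3 is estimated at 2600 nM, with a range from 800 nM to 8000 nM.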

Compound 3, concentration for 50% growth inhibition: 2500 nM
Beside the measured number, compound 3's estimate is 1.0-fold (0.02 log units) above it, and the stated range covers the measured number.
By their numbers in this assay, from the lowest: compounds 1, 3 and 2 (each within the scatter of the next).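

Putting 2,3-dihydro-1,4-benzodioxin-2-yl in place of 3-chlorophenyl gives a 1.0-fold lower number from compound 2 to compound 3 (0.02 log units; within the scatter), and putting it in place of 4-chlorophenyl gives a 1.0-fold higher number from compound 1 to compound 3 (0.02 log units; within the scatter). So in this assay, the place on a saturated chain carbon bound to an amine nitrogen takes more than a moved chlorine: a group without chlorine and with two hydrogen-bond acceptors leaves the numbers inseparable. Nothing available explains why these numbers stay together. Open, going by these compounds, is whether a group without any ring at this place, such as a carboxylic acid or a simple methyl, would also leave the number inseparable.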